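Aryl triazenes: removing one carbamoyl from compound 1

The source may hold more compounds than are shown below. What is called first, only, known or untested is meant among the compounds shown, and "the series" means these compounds.

Measured so far:
compound 1 `CN(C)/N=N/c1cc(C(N)=O)cc(C(N)=O)c1` — 3.27
compound 2 `CCCCN(C)/N=N/c1ccc(CCC(=O)OCC)cc1` — 3.02

Both compounds were tested in a functional assay on L1210 cells (Mus musculus) for antiproliferative activity; a lower number here means a less potent compound, a higher number a more potent compound, by a factor of ten per unit of this negative logarithm. Compound 1 gives 3.27 there. Compound 2 gives 3.02. The two numbers differ by less than the scatter of repeated measurements, so compound 1 and compound 2 cannot be told apart in this assay; compound 1 simply stands as one of two indistinguishable values.

The next compound is compound 3 `CN(C)/N=N/c1cccc(C(N)=O)c1`, which differs from compound 1 in one place: hydrogen in place of carbamoyl on an aromatic carbon. The shared core of compound 1 is otherwise kept. Within the data shown here, no measured pair shows such a change, so there is no direct precedent for its size or direction.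

The step expected in this assay is a number 0.17 log units lower from compound 1 to compound 3 (within the scatter), that is, no change beyond the scatter, with a slight downward lean. Compound 3 is estimated at 3.1, with a range from 2.6 to 3.6, anchored only because compound 1 gives 3.27.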

Compound 3, logarithm of the reciprocal of the active concentration, log(1/C): 3.8
For compound 3 the middle estimate is 0.70 log units below the measured one, and the stated range ends below it.
By their numbers in this assay, from the lowest: compounds 2 and 1 (each within the scatter of the next); then compound 3.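

In this assay, among these compounds, hydrogen in place of carbamoyl on an aromatic carbon gives a number 0.53 log units higher from compound 1 to compound 3 (beyond the scatter) and is the first single change to stand clear of the scatter. This position, meta to a carbamoyl group and meta to a group of 5 heavy atoms, therefore does not need its carbamoyl to retain the number in this assay; with one carbamoyl gone, the value rises rather than falls, although this reading rests on a single pair. Nothing available bears on why the number rises, and the change remains an observation without an assigned origin.

As far as these compounds go, it remains open whether the rise belongs to the loss of the carbamoyl itself or whether other groups on the same aromatic carbon, such as a methyl, a chlorine, an amine or a carboxylic acid, would give a similar number. Also open, from the compounds shown here alone, is whether replacing the remaining carbamoyl of compound 3 with hydrogen, or with a carboxylic acid, would continue the same direction or reverse it.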